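Aryl ether to benzyl swap on the shared core

A few compounds are considered here, and "the series" means these few. Any claim that something is new, unique, unknown or untested is made for them only; others in the source may bear on it.

Working notes on permeability in an ADME assay for permeability, using PAMPA, with a stated time of 30 min, at pH 7.4; a lower number here means that the compound crosses the layer more slowly, a higher number that the compound crosses the layer faster. Compound 2 `COc1ccc(Oc2ccc3c(NCCCNCc4cccc(OC)c4O)ccnc3c2)cc1` gives 317 10^-6 cm/s. Compound 3 `COc1ccc(Oc2ccc3c(NCCCNCc4ccco4)ccnc3c2)cc1` gives 317 10^-6 cm/s; the step of no change at the digits printed from compound 2 to compound 3 (within the scatter) shows that swapping the group on the saturated chain carbon bound to an amine nitrogen leaves the read-out where it was. Compound 1 `COc1ccc(F)cc1CNCCCNc1ccnc2cc(C3CCCCC3)ccc12` gives 23 10^-6 cm/s, the lowest of the three numbers; it differs from compound 2 at more than one place, so its number cannot be tied to any single change. Compound 2 therefore stands level with compound 3, the two together the highest of the three numbers, and well apart from compound 1.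

Compound 4 `COc1cccc(CNCCCNc2ccnc3cc(Cc4cc(C)cc(C)c4)ccc23)c1O` is not yet measured. It differs from compound 2 as follows: 3,5-dimethylbenzyl in place of 4-methoxyphenoxy on an aromatic carbon. Going by the values given here, no measured step touches this aromatic carbon; the only measured step, no change at the digits printed from compound 2 to compound 3 (within the scatter), sits elsewhere and gives no guide to size here. The step is expected to be a 2.6-fold lower number from compound 2 to compound 4 (0.42 log units; beyond the scatter), with wide uncertainty. Compound 4 is estimated at 120 10^-6 cm/s, between 30 10^-6 cm/s and 350 10^-6 cm/s.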

Compound 4, apparent permeability: 23 10^-6 cm/s
Compound 4: the middle estimate sits 5.2-fold (0.72 log units) above what was measured; measured number below the stated range.
By their numbers in this assay, from the lowest: compounds 1 and 4 (each within the scatter of the next); then compounds 2 and 3 (each within the scatter of the next).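

In this assay, going by these compounds alone, the first measured change on this aromatic carbon gives a 14-fold lower number from compound 2 to compound 4 (1.14 log units; beyond the scatter), so the read-out is sensitive at this place, unlike the earlier step on the saturated chain carbon, no change at the digits printed from compound 2 to compound 3 (within the scatter). The size of the step comes with a swap that keeps 9 heavy atoms and one six-membered aromatic ring of carbon only, while 2 oxygen atoms and 2 hydrogen-bond acceptors leave and none enter. No measurement at hand bears on the cause of this step.

The swap changes the ether oxygen and the ring substituents together, and a 4-methoxybenzyl or a 3,5-dimethylphenoxy on this aromatic carbon would separate the two. On these data alone, whether the step holds with the furan-2-yl of compound 3 in place of the 2-hydroxy-3-methoxyphenyl remains open.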